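The source may report more compounds than this note shows. Statements on the series, on what has been measured and on what is new or still open speak of the compounds shown alone.

Of the compounds shown here, two have been measured in an ADME assay on C8166 cells (Homo sapiens) for cytotoxicity, read by colorimetric assay and MTT assay; on this read-out higher numbers stand for lower toxicity in this test and lower numbers for higher toxicity in this test. Compound 1 `Cc1cc(C)cc(C(=O)c2c(OCC(=O)Nc3ccc(S(N)(=O)=O)cc3C)ccc3ccccc23)c1` gives 39100 nM, and compound 2 `Cc1cc(S(N)(=O)=O)ccc1NC(=O)COc1ccc2cc(Br)ccc2c1C(=O)c1cccc(F)c1` gives 31000 nM; these two numbers sit within the scatter of each other, so compound 2 is not set apart from compound 1. Compound 3 `Cc1cc(C)cc(C(=O)c2c(OCC(=O)Nc3ccc(S(N)(=O)=O)cc3C)ccc3cc(Br)ccc23)c1` has not yet been measured. Its change from compound 2 is 3,5-dimethylphenyl in place of 3-fluorophenyl on a carbonyl carbon. Compound 1, which already carries 3,5-dimethylphenyl on the carbonyl carbon and gives 39100 nM, suggests that the step of a 1.1-fold higher number from compound 2 to compound 3 (0.05 log units; within the scatter) is expected to stay within the scatter. Compound 3 is therefore estimated at 35000 nM, with a range from 15000 nM to 80000 nM.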

Compound 3, half-maximal cytotoxic concentration: 24500 nM
Compound 3: the middle estimate sits 1.4-fold (0.15 log units) above what was measured; the range from low to high includes it.
By their numbers in this assay, from the lowest: compounds 3, 2 and 1 (each within the scatter of the next).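

In this assay the step of 3,5-dimethylphenyl in place of 3-fluorophenyl on a carbonyl carbon is a 1.3-fold lower number from compound 2 to compound 3 (0.10 log units; within the scatter) and lies within the scatter, so this exchange shows no clear effect when bromo is present. Bromo in place of hydrogen on an aromatic carbon is a 1.6-fold lower number from compound 1 to compound 3 (0.20 log units; within the scatter) and also lies within the scatter, so neither change sets compound 3 apart. No measurement at hand explains either step. Still open, as far as these compounds go, is whether an amine or a carboxylic acid on the phenyl group at the carbonyl carbon would move the number beyond the scatter. The same holds for chloro or methoxy in place of bromo.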